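Replacing methoxy with cyano on compound 3

A few compounds are considered here, and "the series" means these few. Any claim that something is new, unique, unknown or untested is made for them only; others in the source may bear on it.

Measured in a functional assay on MDA-MB-231 cells (Homo sapiens) for antiproliferative activity, read by MTT assay, with a stated time of 48 h; a higher number here means a weaker inhibitor, a lower number a stronger inhibitor:
- compound 1 `C=CS(=O)(=O)N1CCN(c2ncnc3sc(-c4ccc(N5CCN(C)CC5)cc4)cc23)CC1`: 7550 nM
- compound 2 `CCS(=O)(=O)N1CCN(c2ncnc3sc(-c4ccc(N5CCN(C)CC5)cc4)cc23)CC1`: 7330 nM
- compound 3 `COc1ccc(NC(=O)N2CCN(c3ncnc4sc(-c5ccc(N6CCN(C)CC6)cc5)cc34)CC2)cc1`: 20900 nM

Of these three, compound 3 has the highest number, 20900 nM, and its gaps to the other two lie beyond the scatter. Compound 4 `CN1CCN(c2ccc(-c3cc4c(N5CCN(C(=O)Nc6ccc(C#N)cc6)CC5)ncnc4s3)cc2)CC1` differs from it at one place: cyano in place of methoxy on an aromatic carbon. This is cyano in place of methoxy on an aromatic carbon, para to a large group.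

Within the data shown here, no measured step changes this substituent alone. The closest evidence comes from exchanges of the whole group on the amine nitrogen in a ring. These are a 2.8-fold higher number from compound 1 to compound 3 (0.44 log units; beyond the scatter) and a 2.9-fold higher number from compound 2 to compound 3 (0.46 log units; beyond the scatter), both modest, while a 1.0-fold lower number from compound 1 to compound 2 (0.01 log units; within the scatter) stays within the scatter.

A swap of only the outer substituent is therefore expected to give a step no larger than those two in this assay, probably none beyond the scatter, and the data favour no direction. The expected change is small, a 1.2-fold lower number from compound 3 to compound 4 (0.09 log units; within the scatter). For compound 4 the estimated value is 17000 nM, with an expected range from 7000 nM to 40000 nM.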

Compound 4, half-maximal inhibitory concentration: 3930 nM
Beside the measured number, compound 4's estimate is 4.3-fold (0.64 log units) above it; the whole stated range lies above it.
By their numbers in this assay, from the lowest: compounds 4, 2 and 1 (each within the scatter of the next); then compound 3.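

In this assay, among these compounds, the step of a 5.3-fold lower number from compound 3 to compound 4 (0.73 log units; beyond the scatter) is the first reading of this substituent alone, and it shows that an exchange on an aromatic carbon para to a large group, with the rest of the (4-methoxyphenyl)carbamoyl group unchanged, can carry the number beyond the scatter. The carbamoyl group as such therefore does not set a compound apart from the sulfonyl compounds, since the cyano compound shows a 1.9-fold lower number from compound 2 to compound 4 (0.27 log units; within the scatter) and a 1.9-fold lower number from compound 1 to compound 4 (0.28 log units; within the scatter), both within the scatter. Nothing measured here bears on why the exchange has this effect.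

With only methoxy and cyano at this place, no trend across substituents can be drawn. The compounds shown leave open how chloro, an amine or a carboxylic acid on that carbon would read in this assay.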